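A few compounds are considered here, and "the series" means these few. Any claim that something is new, unique, unknown or untested is made for them only; others in the source may bear on it.

Working notes on the series. Compound 1 `CCCS(=O)(=O)Nc1ccc(Cl)c(C(=O)Nc2cnc3[nH]ncc3c2)c1F` and compound 2 `CCCS(=O)(=O)Nc1ccc(F)c(C(=O)Nc2cnc3[nH]nc(OC)c3c2)c1F` have both been run in an in vivo ADME assay on the whole organism (strain CD-1) for pharmacokinetics, with Mus musculus as the target; a higher number here means faster removal of the compound, a lower number slower removal: compound 1 gives 2.3 mL/min/kg and compound 2 gives 1.3 mL/min/kg. Compound 2 has the lower of the two numbers, but the gap to compound 1 is within the scatter, so neither can be called the slower-cleared one. Compound 3 `CCCS(=O)(=O)Nc1ccc(F)c(C(=O)Nc2cnc3[nH]ncc3c2)c1F` has not yet been run in this assay. It differs from compound 2 by hydrogen in place of methoxy on an aromatic carbon. Among the measured compounds shown here, no step of this kind has been measured, so the step is expected to be small in either direction, a 1.4-fold higher number from compound 2 to compound 3 (0.14 log units; within the scatter), with nothing beyond the scatter anticipated. Compound 3 is expected to show about 1.8 mL/min/kg in this assay, within 0.9 mL/min/kg to 3.6 mL/min/kg.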

Compound 3, clearance in the Mus musculus assay: 15 mL/min/kg
Compound 3: middle estimate off by 8.3-fold (0.92 log units), on the low side; the measured number lies above the stated range.
By their numbers in the Mus musculus assay, from the lowest: compounds 2 and 1 (each within the scatter of the next); then compound 3.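

On an aromatic carbon of the five-membered ring, hydrogen in place of methoxy is far from a neutral change in the Mus musculus assay: a 12-fold higher number from compound 2 to compound 3 (1.06 log units; beyond the scatter). The chloro site also counts in the same assay, with fluoro in place of chloro giving a 6.5-fold higher number from compound 1 to compound 3 (0.81 log units; beyond the scatter). In a physicochemical assay for solubility, read by HPLC, in phosphate buffer, with a stated time of 24 h, at pH 7.4 (a higher number here means a more soluble compound, a lower number a less soluble compound), compound 2 gives 9 ug/mL and compound 3 gives 150 ug/mL, so within this pair compound 3 has the higher number in both assays.

On these data alone, whether an ethoxy group or an amine on this carbon would keep clearance as low as methoxy does remains open. Also open, as far as these compounds go, is how chloro and methoxy behave when carried together on the shared core.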